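Swapping a Methylphenyl Amide for a Thiophene Ring

The source may hold more compounds than are shown below. What is called first, only, known or untested is meant among the compounds shown, and "the series" means these compounds.

Compound 3 `Cc1ccccc1C(=O)Nc1cc(-c2ccccc2)nn1-c1ccccc1` stands at the edge of what an assay on CHO cells with metabotropic glutamate receptor 5 (Homo sapiens) as the target (on this read-out lower numbers stand for an effect already at smaller amounts and higher numbers for an effect only at larger amounts of compound), can report: it gives only > 10000 nM, which is a limit of the measurement rather than a number (the limit of > 10000 nM in this assay, at which 1 of the 3 values shown sits). Compound 1 `O=C(Nc1cc(-c2ccccc2)nn1-c1ccccc1)c1ccccc1` gives 40 nM in this assay, and compound 2 `O=C(Nc1cc(-c2ccccc2)nn1-c1ccccc1)c1ccccc1F` gives 75 nM. Going by the values given here, two measured steps bear on the next change: an at least 250-fold higher number from compound 1 to compound 3 (2.39 log units; beyond the scatter), and an at least 130-fold higher number from compound 2 to compound 3 (2.12 log units; beyond the scatter), whereas a 1.9-fold higher number from compound 1 to compound 2 (0.27 log units; within the scatter). Compound 4 `O=C(Nc1cc(-c2ccccc2)nn1-c1ccccc1)c1ccsc1` makes the change (thiophen-3-yl in place of 2-methylphenyl on a carbonyl carbon). The entering ring carries no methyl, and both steps in which a methyl entered were large. The step from compound 3 to compound 4 is therefore expected to be an at least 120-fold lower number from compound 3 to compound 4 (2.09 log units; beyond the scatter). Compound 4 is estimated at 80 nM, between 20 nM and 600 nM.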

Compound 4, half-maximal effective concentration: 1800 nM
The estimate for compound 4 lay 23-fold (1.35 log units) below the measured number; measured number outside the range, above it.
By their numbers in this assay, from the lowest: compounds 1 and 2 (each within the scatter of the next); then compound 4. At a limit, above all of these: compound 3.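

In this assay, thiophen-3-yl on this carbonyl carbon restores a measurable number, with an at least 5.5-fold lower number from compound 3 to compound 4 (0.74 log units; beyond the scatter) as the step out of the 2-methylphenyl compound. Even without a methyl, the new ring still falls well short of the two six-membered rings, with a 45-fold higher number from compound 1 to compound 4 (1.65 log units; beyond the scatter) and a 24-fold higher number from compound 2 to compound 4 (1.38 log units; beyond the scatter) as the steps from them. The first step gives only a minimum size, since compound 3 sits at a limit: the limit of > 10000 nM in this assay, at which 1 of the 4 values shown sits.

On these data alone, how a pyridin-3-yl ring, a furan-3-yl ring or a simple amine would behave on this carbonyl carbon remains open.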